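This account rests on a few compounds, and the source may have more. Where it says the series, first, only, none or still open, it means among the compounds named here.

Compound 1, `CS(=O)(=O)Nc1ccc2c(c1)S(=O)(=O)N=C(C1=C(O)C3CCCCC3N(Cc3ccc(F)cc3)C1=O)N2`, is measured in an ADME assay on Huh-7 cells (Homo sapiens) for cytotoxicity, with a stated time of 72 h; on this read-out higher numbers stand for lower toxicity in this test and lower numbers for higher toxicity in this test; there compound 1 gives > 33000 nM, which is a limit of the assay. Compound 2, `CC(C)(C)CCN1C(=O)C(C2=NS(=O)(=O)c3cc(NS(C)(=O)=O)ccc3N2)=C(O)C2CCCCC21`, also stands at a limit: in this assay compound 2 gives > 33000 nM. The step that the two limits leave unreadable from compound 1 to compound 2 is thus unreadable, as both values sit on (the limit of > 33000 nM in this assay, at which 2 of the 2 values shown sit). Compound 3, `CS(=O)(=O)Nc1ccc2c(c1)S(=O)(=O)N=C(C1=C(O)[C@@H]3CCCC[C@@H]3N(Cc3ccc(F)cc3)C1=O)N2`, is not yet measured; it differs from compound 1 in that (the two compounds have the same atoms and bonds; at least one stereo element is drawn with a configuration in one of them and without one in the other: 2 of 2 stereo elements differ; a stereocentre at a saturated ring carbon is drawn without a configuration in compound 1 and R in compound 3; a stereocentre at a saturated ring carbon is drawn without a configuration in compound 1 and S in compound 3). Within the data shown here, no measured step bears on drawing a configuration where none was drawn, and the one comparison at hand is unreadable, so no step beyond the scatter is expected in this assay. Compound 3 is therefore estimated at 33000 nM, between 20000 nM and 100000 nM, and the expected step is a number no higher from compound 1 to compound 3 (the limit leaves the size open).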

Compound 3, half-maximal cytotoxic concentration: > 33000 nM
Compound 3 was reported as a limit (the forecaster's own chance of this, stated with the estimate: 85%); the middle value sits exactly at the limit.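

In this assay compound 3, like compound 1, stands at a limit, so no step can be read between them: the limit of > 33000 nM in this assay, at which 3 of the 3 values shown sit. The compounds shown leave open whether a drawn configuration, or neopentyl in place of 4-fluorophenyl, changes the half-maximal cytotoxic concentration at all.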